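Phenyl for Methyl on the Core of Compound 1

A few compounds are considered here, and "the series" means these few. Any claim that something is new, unique, unknown or untested is made for them only; others in the source may bear on it.

Compound 1 `Cc1ccc2c(c1)c(=O)c(C(=O)Nc1ccc(Oc3ncnc4[nH]cc(-c5ccccc5)c34)c(F)c1)c(C)n2C` gives 100 nM in an assay on isolated protein for inhibition of tyrosine-protein kinase receptor UFO (Homo sapiens), read by FRET and Z'-LYTE, with a stated time of 1.5 h; on this read-out lower numbers stand for stronger inhibition and higher numbers for weaker inhibition.
Compound 2 `CCCCn1c(C)c(C(=O)Nc2ccc(Oc3ncnc4[nH]cc(-c5ccccc5)c34)c(F)c2)c(=O)c2cc(C)ccc21` gives 480 nM in this assay.

Compound 1 stands lowest of the two numbers; compound 2 lies a 4.8-fold higher number from compound 1 to compound 2 (0.68 log units; beyond the scatter) away. Compound 3 `Cc1c(C(=O)Nc2ccc(Oc3ncnc4[nH]cc(-c5ccccc5)c34)c(F)c2)c(=O)c2cc(-c3ccccc3)ccc2n1C` differs from compound 1 by phenyl in place of methyl on an aromatic carbon. The only measured step concerns a different place, the saturated chain carbon bound to an aromatic nitrogen, so nothing shown bears on a change at this aromatic carbon. With no guide, compound 3 is expected to stay within the scatter of compound 1, estimated at 150 nM with a range of 40 nM to 600 nM, a step of a 1.5-fold higher number from compound 1 to compound 3 (0.18 log units; within the scatter).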

Compound 3, half-maximal inhibitory concentration: > 10000 nM
Compound 3: only a limit was reported; the forecaster's own chance of this, stated with the estimate: 3%; middle value at least 66-fold (1.82 log units) from the limit.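

The aromatic carbon that carries methyl in compound 1 proves highly sensitive to substitution, as phenyl in place of methyl gives an at least 100-fold higher number from compound 1 to compound 3 (2.00 log units; beyond the scatter). In this assay, for the compounds shown here, compound 3 gives only a limit and not a number: the limit of > 10000 nM in this assay, at which 1 of the 3 values shown sits. The earlier compounds showed a change only on the saturated chain carbon bound to an aromatic nitrogen, whereas this step shows that activity also depends on the group at this aromatic carbon. Only methyl and phenyl are shown at this position, so how hydrogen, a fluorine atom, an ethyl group or a methoxy group would fare there stays open.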